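Removing the chlorobenzoyl group: what happens to growth inhibition

This account rests on a few compounds, and the source may have more. Where it says the series, first, only, none or still open, it means among the compounds named here.

Of the compounds shown here, three have been tested in a functional assay on PC-3 cells (Homo sapiens) for cytotoxicity, read by sulforhodamine B assay, with a stated time of 72 h; a higher number here means a weaker inhibitor of growth, a lower number a stronger inhibitor of growth. Compound 1 `CCCCCCCCC(=O)N1c2ccccc2CCC1C(=O)Nc1ccccc1C(F)(F)F` gives 4320 nM, compound 2 `O=C(Nc1cc(C(F)(F)F)cc(C(F)(F)F)c1)C1CCc2ccccc2N1C(=O)c1ccc(Cl)cc1` gives 4230 nM, and compound 3 `O=C(Nc1ccccc1O)C1CCc2ccccc2N1` gives 4310 nM. Compound 2 shows the lowest of the three numbers, yet its distance to compound 3 and to compound 1 lies within the scatter of repeated measurements, so the three values are effectively indistinguishable.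

The next compound, compound 4 `O=C(Nc1cc(C(F)(F)F)cc(C(F)(F)F)c1)C1CCc2ccccc2N1`, differs from compound 2 in one place: hydrogen in place of (4-chlorophenyl)carbonyl on a nitrogen on an aromatic ring in a ring. Among the measured compounds shown here, no measured pair shows this same change in this assay, so there is no step to lean on. Because compound 2 gives 4230 nM and compound 1 gives 4320 nM despite quite different groups on the shared core, the measured values sit close together. The expectation is therefore that compound 4 also stays near this cluster, with a step of a 1.1-fold higher number from compound 2 to compound 4 (0.03 log units; within the scatter) that is not beyond the scatter. Compound 4 is therefore estimated at 4500 nM, within a range of 1500 nM to 14000 nM.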

Compound 4, concentration for 50% growth inhibition: 8120 nM
For compound 4 the middle estimate is 1.8-fold (0.26 log units) below the measured one; measured number inside the range.
By their numbers in this assay, from the lowest: compounds 2, 3, 1 and 4 (each within the scatter of the next).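

Among the compounds shown here, this is the first direct comparison at this position: with the (4-chlorophenyl)carbonyl group on the ring nitrogen replaced by hydrogen, this assay gives a 1.9-fold higher number from compound 2 to compound 4 (0.28 log units; within the scatter). That step lies within the scatter, so this one pair shows no measurable difference in growth inhibition between carrying this large group and carrying only hydrogen there. No measurement available here explains this result.

A single pair cannot show whether the same would hold with the other groups on the shared core, so it gives no general rule for this position. It also leaves open what a small acetyl group, a methyl group or a group bearing a carboxylic acid would do on this nitrogen.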